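Bromo in place of isopropyl on the aryl thiocarbamate

A few compounds are considered here, and "the series" means these few. Any claim that something is new, unique, unknown or untested is made for them only; others in the source may bear on it.

Compound 1, `S=C(Nc1ccccc1Cl)OCCc1ccccn1`: > 100000 nM
Compound 2, `Fc1cccc(NC(=S)OCCc2ccccn2)c1`: >= 100000 nM
Compound 3, `CC(C)c1ccc(NC(=S)OCCc2ccccn2)cc1`: 45000 nM

Of the compounds shown here, three sharing one core have been tested in an ADME assay on MT4 cells (Homo sapiens) for cytotoxicity, read by MTT assay; a higher number here means that more compound is tolerated, a lower number that less compound is tolerated. Compound 1 gives only > 100000 nM, a limit of the assay rather than a number. Compound 2 likewise stops at the limit >= 100000 nM. Going by the values given here, compound 3 is the only one with a measured number, 45000 nM, and so it alone gives a fixed point among the three. Compound 4, `S=C(Nc1ccc(Br)cc1)OCCc1ccccn1`, differs from compound 3 by bromo in place of isopropyl on an aromatic carbon. Among the compounds with values here, no step between measured compounds is known, so the size of this change is open. Since both halogenated relatives sit at limits (the limit of > 100000 nM in this assay, at which 1 of the 3 values shown sits, (the limit of >= 100000 nM in this assay, at which 1 of the 3 values shown sits)), a shift toward higher tolerance, beyond the scatter, is expected. Compound 4 is expected at 80000 nM, ranging from 35000 nM to 200000 nM. The expected step is a 1.8-fold higher number from compound 3 to compound 4 (0.25 log units; within the scatter).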

Compound 4, half-maximal cytotoxic concentration: 37000 nM
Compound 4: the middle estimate sits 2.2-fold (0.33 log units) above what was measured; low and high end bracket the measured number.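

The series now holds its first step that can be read: in this assay, bromo in place of isopropyl on an aromatic carbon gives a 1.2-fold lower number from compound 3 to compound 4 (0.09 log units; within the scatter). At this place, para to a large group, the two groups are not told apart by this read-out. Nothing measured here accounts for this step. From the compounds shown here alone, whether an amine, a carboxylic acid or a longer chain at the same place would move the number beyond the scatter stays open. So does whether bromo would give the same result on another aromatic carbon.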